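From Cyclohexyl to 4-Chlorophenyl on the Ring Nitrogen

A few compounds are considered here, and "the series" means these few. Any claim that something is new, unique, unknown or untested is made for them only; others in the source may bear on it.

In a functional assay on HeLa cells (Homo sapiens) for antiproliferative activity, read by MTT assay, with a stated time of 72 h (on this read-out higher numbers stand for weaker inhibition and lower numbers for stronger inhibition), compound 1 (`O=C1COc2ccc(-c3cnc(Cl)c(NS(=O)(=O)c4ccc(F)cc4)c3)cc2N1`) stands at 15600 nM and compound 2 (`O=C1COc2ccc(-c3cnc4ccccc4c3)cc2N1C1CCCCC1`) at 19700 nM so compound 2 lies within the scatter of compound 1. Compound 3 (`O=C1COc2ccc(-c3cnc4ccccc4c3)cc2N1c1ccc(Cl)cc1`) differs from compound 2 by 4-chlorophenyl in place of cyclohexyl on an amide-type nitrogen in a ring. Among the compounds with values here, no measured pair shows the effect of such a change, so no shift beyond the scatter is expected in either direction. A step of a 1.3-fold lower number from compound 2 to compound 3 (0.12 log units; within the scatter) is expected here and would stay within the scatter. For compound 3 the estimate is 15000 nM with an expected range from 4000 nM to 50000 nM on this read-out.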

Compound 3, half-maximal inhibitory concentration: > 40000 nM
Compound 3 gave a limit, no number; the forecaster's own chance of this, stated with the estimate: 15%; middle value at least 2.6-fold (0.42 log units) from the limit.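

In this assay compound 3 gives > 40000 nM, a limit of the assay and not a number. Within the data shown here, putting 4-chlorophenyl in place of cyclohexyl on the amide-type nitrogen in a ring gives an at least 2.0-fold higher number from compound 2 to compound 3 (0.30 log units; that floor lies within the scatter), the first step that can be read at this position. Its true size remains unknown, and its floor alone does not separate the two compounds, for one reason: the limit of > 40000 nM in this assay, at which 1 of the 3 values shown sits.

From the compounds shown here alone, whether a methyl group or a longer chain ending in an amine on this nitrogen would give a value short of that limit remains open.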